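The compounds below may be only part of what the source reports. "The series", "measured", "known", "first", "only" and "open" are said of these compounds alone.

Of the compounds shown here, two built on the same core have been measured so far. In a functional assay on PC-3 cells (Homo sapiens) for antiproliferative activity, read by MTT assay, with a stated time of 72 h (a higher number here means a weaker inhibitor, a lower number a stronger inhibitor), compound 1 `C/C=C/C(=O)Nc1cc2c(N3CCc4ccccc43)ncnc2cc1OC` gives 8120 nM, the higher of the two numbers. Among the measured compounds shown here, compound 2 `C/C=C/C(=O)Nc1cc2c(N3CCc4ccccc43)ncnc2cc1O[C@@H]1CCOC1`, which differs from it only at the oxygen on the aromatic ring, gives 5220 nM in this assay; the one measured step, a 1.6-fold lower number from compound 1 to compound 2 (0.19 log units; within the scatter), stays within the scatter. Compound 3 `COc1cc2ncnc(N3CCc4ccccc43)c2cc1NC(=O)/C=C/CN1CCCC1` changes compound 1 at a different place altogether: pyrrolidin-1-yl in place of hydrogen on a saturated chain carbon bound to a double-bonded chain carbon. For the measured compounds named here, no measured step touches that part of the molecule, so that step offers no guide, and there is no basis in these numbers for expecting a move beyond the scatter in either direction. Compound 3 is therefore expected to give about 5000 nM in this assay, with a range from 1500 nM to 16000 nM. The step this estimate implies is a 1.6-fold lower number from compound 1 to compound 3 (0.21 log units; within the scatter).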

Compound 3, half-maximal inhibitory concentration: 2620 nM
Beside the measured number, compound 3's estimate is 1.9-fold (0.28 log units) above it; the range from low to high includes it.
By their numbers in this assay, from the lowest: compounds 3, 2 and 1 (each within the scatter of the next, the first and the last beyond it).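

In this assay, among the compounds shown here, putting pyrrolidin-1-yl on the saturated chain carbon bound to a double-bonded chain carbon brings a 3.1-fold lower number from compound 1 to compound 3 (0.49 log units; beyond the scatter) and is a modest change, but it is the first step in this set to lie beyond the scatter. For the compounds shown here, the step at the oxygen on the aromatic ring, a 1.6-fold lower number from compound 1 to compound 2 (0.19 log units; within the scatter), did not, so the chain is the first place here where a single change clearly moves the number. No supporting measurement bears on why the number moves.

On these data alone, whether the ring nitrogen matters stays open, and a cyclopentyl group, a dimethylamino group or morpholin-4-yl on the same carbon would help to separate these possibilities. Also open, as far as these compounds go, is what oxolan-3-yl on the oxygen and pyrrolidin-1-yl on the chain would give together in one molecule.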